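Swapping the alkoxy arm for a fluorophenyl ring

A few compounds are considered here, and "the series" means these few. Any claim that something is new, unique, unknown or untested is made for them only; others in the source may bear on it.

Of the compounds shown here, three that share one amide core have been measured in an assay on CHO cells for inhibition of sodium- and chloride-dependent glycine transporter 1 (Homo sapiens), read by scintillation counting; on this read-out higher numbers stand for an effect only at larger amounts of compound and lower numbers for an effect already at smaller amounts. Compound 1 `C[C@H](Oc1ccc(S(C)(=O)=O)cc1C(=O)N1Cc2ccc(-c3ccccn3)cc2C1)C(F)(F)F` gives 84 nM. Compound 2 `CC(C)Oc1ccc(S(C)(=O)=O)cc1C(=O)N1Cc2ccc(C3CCOCC3)cc2C1` gives 28 nM. Compound 3 `CS(=O)(=O)c1ccc(OCCC(F)(F)F)c(C(=O)N2Cc3cc(C(F)(F)F)cnc3C2)c1` gives 111 nM. Among these three numbers compound 2 stands lowest, and its distance to compound 1 and to compound 3 is in each case beyond the usual scatter, so compound 2 is the most potent of the three measured.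

Compound 4 `CS(=O)(=O)c1ccc(-c2ccc(F)cc2)c(C(=O)N2Cc3ccc(C4CCOCC4)cc3C2)c1` has not yet been measured. It differs from compound 2 in one place: 4-fluorophenyl in place of isopropoxy on an aromatic carbon. The change therefore puts 4-fluorophenyl in place of isopropoxy on an aromatic carbon, ortho to a large group and para to the methylsulfonyl group. Among the measured compounds shown here, all three measured compounds carry an alkoxy group at that place, so there is no measured pair that shows what a carbon-linked aromatic ring does there. The replacement is sizeable, and the account treats it as a step of uncertain direction but more likely towards a higher number. Compound 4 is expected to give 100 nM, within a range from 30 nM to 400 nM, which would be a step of a 3.6-fold higher number from compound 2 to compound 4 (0.55 log units; beyond the scatter) from compound 2, estimated rather than known.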

Compound 4, half-maximal effective concentration in the sodium- and chloride-dependent glycine transporter 1 assay: 16 nM
Compound 4: middle estimate off by 6.3-fold (0.80 log units), on the high side; the whole stated range lies above it.
By their numbers in the sodium- and chloride-dependent glycine transporter 1 assay, from the lowest: compounds 4 and 2 (each within the scatter of the next); then compounds 1 and 3 (each within the scatter of the next).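

In the sodium- and chloride-dependent glycine transporter 1 assay the exchange of isopropoxy for 4-fluorophenyl comes out as a 1.8-fold lower number from compound 2 to compound 4 (0.24 log units; within the scatter), so this place, on an aromatic carbon para to a methylsulfonyl group, can carry a carbon-linked aromatic ring with no change beyond the scatter. Among the compounds shown here, that is something compounds 1, 2 and 3 could not show, since all of them hold an alkoxy group there and no measured pair had tested anything else at this place. The change is far from neutral overall, however, and what it alters among the read-outs shown is not the transporter number but the one in a physicochemical assay for solubility; a higher number here means a more soluble compound, a lower number a less soluble compound: the measured solubility of compound 2, 191 ug/mL, and of compound 4, 15 ug/mL, a 13-fold lower number (1.10 log units; beyond the scatter)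

For the compounds shown here, what remains open is whether this holds beyond a single pair, since the exchange is seen only on the core of compound 2 and with only one aromatic ring, so its outcome on the cores of compound 1 and compound 3 is unknown. Going by these compounds, it is also open whether a different group at this place, such as a piperazine amine or a carboxylic acid, would keep the number in the sodium- and chloride-dependent glycine transporter 1 assay while giving a solubility closer to that of compound 2. In the physicochemical assay compound 2 gives 191 ug/mL and compound 4 gives 15 ug/mL.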